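This account rests on a few compounds, and the source may have more. Where it says the series, first, only, none or still open, it means among the compounds named here.

Measured compounds:
- compound 1 `C=C1CC[C@@H]2[C@](C)(CO)[C@H](O)CC[C@@]2(C)[C@@H]1/C=C/C1=C/C(=C/C)OC1=O`: 15.1%
- compound 2 `C=C1CC[C@@H]2[C@](C)(CO)[C@H](O)CC[C@@]2(C)[C@@H]1/C=C/C1=C/C(=C/CCC)OC1=O`: 43.5%
- compound 3 `C=C1CC[C@@H]2[C@](C)(CO)[C@H](O)CC[C@@]2(C)[C@@H]1/C=C/C1=C/C(=C/c2ccc(Cl)cc2)OC1=O`: "not active" (no number reported)

In an assay on isolated protein for inhibition of Maltase-glucoamylase (Homo sapiens), tested at 100 uM (a lower number here means less inhibition, a higher number more inhibition at the concentration tested (going by the name of the read-out)), compound 1 gives 15.1% and stands as the lower of the two numbers in the set. Compound 2 gives 43.5% in this assay, and compound 3 is reported as "not active" (no number reported) in this assay, without a number.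

Compound 4 `C=C1CC[C@@H]2[C@](C)(CO)[C@H](O)CC[C@@]2(C)[C@@H]1/C=C/C1=C/C(=C/c2ccc(OC)cc2)OC1=O` is not yet measured. It differs from compound 1 by 4-methoxyphenyl in place of methyl on a double-bonded chain carbon bound to a double-bonded ring carbon.

Among the measured compounds shown here, the one measured step that bears on this position is a number 28.4 percentage points higher from compound 1 to compound 2 (beyond the scatter), a chain lengthening that raised inhibition. The change to compound 4 is of a different kind: an aromatic group enters. For the measured compounds named here, the only aromatic analogue, compound 3, is reported as not active in this assay, and no step to it is computed. Weighing the rise seen in compound 2 against the lack of a number for compound 3, the step to compound 4 is expected to be small or none beyond the scatter, possibly downward: a number 3.1 percentage points lower from compound 1 to compound 4 (within the scatter). The estimate for compound 4 in this assay is 12%, within 0% to 35%.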

Compound 4, a percentage reported as inhibition, at one concentration (the size of the read-out at that concentration, not a potency): 100%
For compound 4 the middle estimate is 88 percentage points below the measured one; measured number outside the range, above it.
By their numbers in this assay, from the lowest: compound 1; then compound 2; then compound 4.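

In this assay, this position on the double-bonded chain carbon takes an aromatic group with a large gain: 4-methoxyphenyl in place of methyl gives a number 84.9 percentage points higher from compound 1 to compound 4 (beyond the scatter), and in place of propyl it gives a number 56.5 percentage points higher from compound 2 to compound 4 (beyond the scatter). An aromatic ring alone does not account for this result, as compound 3, which carries 4-chlorophenyl, is reported as "not active" (no number reported), whereas compound 4 gives 100%, and the two differ only in the group on that ring. No measurement on hand explains this contrast.

Going by these compounds, it remains open whether a hydroxyl, an amine or a carboxylic acid in place of the methoxy group would keep this level of inhibition, and whether a chain longer than propyl would raise inhibition further. A read-out at one concentration also leaves the potency of compound 4 undefined.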